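Chain extension in the chloromethyl ketone series

A few compounds are considered here, and "the series" means these few. Any claim that something is new, unique, unknown or untested is made for them only; others in the source may bear on it.

Two members of the series have numbers in a functional assay on MOLT-3 cells (Homo sapiens); on this read-out higher numbers stand for weaker inhibition and lower numbers for stronger inhibition. Compound 1, `CCCCCCCCCCCCCCCSC[C@H](NC(C)=O)C(=O)CCl`, gives 8600 nM in this assay. Compound 2, `CCCCCCCCCCCCCCCCSC[C@H](NC(C)=O)C(=O)CCl`, in which the chain runs one carbon longer, gives 17300 nM. Within the data shown here, the two numbers sit close together: the step of a 2.0-fold higher number from compound 1 to compound 2 (0.30 log units; within the scatter) places compound 2 beside compound 1 rather than apart from it, and compound 2 is the second of the two numbers available, with compound 1 as its only neighbour.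

Compound 3, `CCCCCCCCCCCCCCCCCCCCCCSC[C@H](NC(C)=O)C(=O)CCl`, is not yet measured. It differs from compound 2 by hexyl in place of hydrogen on a saturated chain carbon, ten or more bonds along the chain from a sulfur. Among the measured compounds shown here, the one step that bears on this change is the chain lengthening a 2.0-fold higher number from compound 1 to compound 2 (0.30 log units; within the scatter), which was within the scatter for a single added carbon. The present change adds six carbons at the same kind of position, so a drift toward higher numbers, larger than that single step, is expected but cannot be anchored to more than one precedent. The expected step is a 2.3-fold higher number from compound 2 to compound 3 (0.36 log units; beyond the scatter). Compound 3 is therefore estimated at 40000 nM in this assay, with a range from 12000 nM to 130000 nM.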

Compound 3, half-maximal inhibitory concentration: > 100000 nM
Compound 3 gave a limit, no number; the forecaster's own chance of this, stated with the estimate: 25%; middle value at least 2.5-fold (0.39 log units) away from the limit.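

Compound 3 carries a limit in this assay, not a number: the limit of > 100000 nM in this assay, at which 1 of the 3 values shown sits. With hexyl in place of hydrogen on a saturated chain carbon, ten or more bonds along the chain from a sulfur, the series now shows an at least 5.7-fold higher number from compound 2 to compound 3 (0.76 log units; beyond the scatter), and the full span of the chain change reads as an at least 11-fold higher number from compound 1 to compound 3 (1.06 log units; beyond the scatter). Among these compounds, the position is therefore not indifferent to chain length: the single added carbon of compound 2 stayed within the scatter, whereas the hexyl change weakens inhibition beyond it, by an amount known only as a lower bound.

The compounds shown leave open whether the loss sets in gradually or abruptly, since propyl in place of hydrogen at this place, or any other chain of intermediate length, does not appear among them. They also leave open whether a shorter chain would give stronger inhibition than compound 1, and whether a chain carrying a carboxylic acid or an amine would hold inhibition at the length of compound 3.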